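A few compounds are considered here, and "the series" means these few. Any claim that something is new, unique, unknown or untested is made for them only; others in the source may bear on it.

The measured compounds in a functional assay on MGC-803 cells (Homo sapiens) for inhibition, read by MTT assay, with a stated time of 72 h; on this read-out higher numbers stand for weaker inhibition and lower numbers for stronger inhibition:
Compound 1 `C#CCSc1nc(NCCC#N)c2ccncc2n1` gives > 80000 nM.
Compound 2 `C#CCSc1nc(Nc2ccc(F)cc2)c2ccncc2n1` gives 15800 nM.
Compound 3 `C#CCSc1nc(Nc2ccc(Cl)cc2)c2ccncc2n1` gives 16400 nM.

The value of compound 1 is only a limit of this assay, not a number, so its place is known only as a bound (the limit of > 80000 nM in this assay, at which 1 of the 3 values shown sits). Compound 4 `C#CCSc1nc(Nc2cccc(O)c2)c2ccncc2n1` differs from compound 1 by 3-hydroxyphenyl in place of 2-cyanoethyl on a nitrogen on an aromatic ring. Going by the values given here, two measured steps bear on this exchange of the 2-cyanoethyl for an aromatic ring on that nitrogen: an at least 5.0-fold lower number from compound 1 to compound 2 (0.70 log units; beyond the scatter) and an at least 4.8-fold lower number from compound 1 to compound 3 (0.68 log units; beyond the scatter), while a 1.0-fold higher number from compound 2 to compound 3 (0.02 log units; within the scatter). A ring bearing a hydroxyl rather than a halogen has not been tried, so the size of the step is uncertain, but a lowering of similar size is expected, an at least 4.4-fold lower number from compound 1 to compound 4 (0.64 log units; beyond the scatter). Compound 4 is therefore estimated at 18000 nM, with a range from 6000 nM to 60000 nM.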

Compound 4, half-maximal inhibitory concentration: 15700 nM
Compound 4: middle estimate off by 1.1-fold (0.06 log units), on the high side; the range from low to high includes it.
By their numbers in this assay, from the lowest: compounds 4, 2 and 3 (each within the scatter of the next). At a limit, above all of these: compound 1.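

In this assay the exchange of 2-cyanoethyl for 3-hydroxyphenyl gives an at least 5.0-fold lower number from compound 1 to compound 4 (0.70 log units; beyond the scatter) and, with compound 1 given only as a limit, that step is only a bound: the limit of > 80000 nM in this assay, at which 1 of the 4 values shown sits. A hydroxyl-bearing ring now joins the halogen-bearing ones, with a 1.0-fold lower number from compound 3 to compound 4 (0.02 log units; within the scatter) and a 1.0-fold lower number from compound 2 to compound 4 (0.00 log units; within the scatter) both within the scatter. So, among these three rings on that nitrogen, changing the ring's substituent shifts the number by no more than the scatter.

On these data alone, whether a ring bearing an amine or a carboxylic acid would behave the same remains open. So does the effect of a longer chain between the nitrogen and the ring.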